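A few compounds are considered here, and "the series" means these few. Any claim that something is new, unique, unknown or untested is made for them only; others in the source may bear on it.

Working notes on the series.

Three compounds share the core; in an assay on microsomes from liver for inhibition of acyl-CoA desaturase 1 (Rattus norvegicus) (on this read-out lower numbers stand for stronger inhibition and higher numbers for weaker inhibition), compound 1 `Cc1ccc(OC2CCN(c3ccc(-n4ccnc4)nn3)CC2)cc1` gives 527 nM, compound 3 `COc1ccccc1OC1CCN(c2ccc(-n3ccnc3)nn2)CC1` gives 543 nM, and compound 2 `OCc1nnc(-c2ccc(N3CCC(Oc4ccccc4C(F)(F)F)CC3)nn2)s1` gives 3.2 nM. Compound 2 therefore holds the lowest number of the three, the nearest value, that of compound 1, lying far beyond the scatter. Within the data shown here, the only step available within measured pairs, a 1.0-fold higher number from compound 1 to compound 3 (0.01 log units; within the scatter), sits on the aryl ether end of the molecule and shows no shift of note.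

Compound 4 `CC(C)(C)c1nnc(-c2ccc(N3CCC(Oc4ccccc4C(F)(F)F)CC3)nn2)o1` differs from compound 2 at the other end: 5-(tert-butyl)-1,3,4-oxadiazol-2-yl in place of 5-(hydroxymethyl)-1,3,4-thiadiazol-2-yl on an aromatic carbon. Among the measured compounds shown here, no measured pair touches this position, so there is no step on record that bears directly on it; the step from compound 1 to compound 3 concerns a different part of the core and only shows that a change there left this assay unmoved. The thiadiazole of compound 2 is the single substituent seen at this place, and its value already sits low. Lacking any step at this position, the expectation is kept near compound 2 with a broad margin, and the step from compound 2 to compound 4 in this assay is expected as a 2.2-fold higher number from compound 2 to compound 4 (0.34 log units; beyond the scatter). For compound 4 the expected value is 7 nM, within 1.5 nM to 40 nM.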

Compound 4, half-maximal inhibitory concentration: 980 nM
Beside the measured number, compound 4's estimate is 140-fold (2.15 log units) below it; the whole stated range lies below it.
By their numbers in this assay, from the lowest: compound 2; then compounds 1, 3 and 4 (each within the scatter of the next).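

In this assay, among these compounds, this place on the aromatic carbon, para to a large group, responds strongly to the change (a 310-fold higher number from compound 2 to compound 4 (2.49 log units; beyond the scatter)), whereas the only earlier step (a 1.0-fold higher number from compound 1 to compound 3 (0.01 log units; within the scatter)) lay at the aryl ether end and stayed within the scatter. Among the compounds shown here, compound 2 and compound 4 share the rest of the structure, so that common part does not secure a low number on its own, and the 5-(hydroxymethyl)-1,3,4-thiadiazol-2-yl group matters here in a way the earlier compounds could not show. No measurement shown gives a reason for the size of this step.

For the compounds shown here, the single step changes the ring and its substituent together, with sulfur leaving, the hydroxymethyl chain giving way to tert-butyl and the hydrogen-bond donor count going from 1 to 0, so these changes cannot be read apart. From the compounds shown here alone, what stays open is how 5-(hydroxymethyl)-1,3,4-oxadiazol-2-yl or 5-(tert-butyl)-1,3,4-thiadiazol-2-yl would read at this place, and whether a carboxylic acid, an amine or a longer chain in place of the hydroxymethyl would hold the low number of compound 2.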